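The source may report more compounds than this note shows. Statements on the series, on what has been measured and on what is new or still open speak of the compounds shown alone.

Compound 1 `FC(F)(F)c1ccc(C2CC(c3ccc(Cl)cc3)=NN2c2ccc(-c3ccccc3)nn2)cc1`: 8330 nM
Compound 2 `COc1ccc(C2=NN(c3ccc(-c4ccccc4)nn3)C(c3ccccc3)C2)cc1`: > 100000 nM

In a functional assay on HepG2 cells (Homo sapiens) for antiproliferative activity, read by MTT assay, with a stated time of 24 h (a higher number here means a weaker inhibitor, a lower number a stronger inhibitor), compound 1 gives 8330 nM. Compound 2 in this assay gives only a limit, > 100000 nM, not a number. Compound 2 therefore stands at the limit of > 100000 nM in this assay, at which 1 of the 2 values shown sits, with no value of its own to compare. Compound 3 `COc1ccc(C2=NN(c3ccc(-c4ccccc4)nn3)C(c3ccc(C(F)(F)F)cc3)C2)cc1` carries trifluoromethyl in place of hydrogen on an aromatic carbon. Among the compounds with values here, no measured pair shows this exact change. Compound 1 also bears a trifluoromethyl group on this ring and gives a number, 8330 nM, so the step from compound 2 to compound 3 is expected to be an at least 3.3-fold lower number from compound 2 to compound 3 (0.52 log units; beyond the scatter), toward stronger inhibition. For compound 3 the estimate is 30000 nM, within 8000 nM to 100000 nM.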

Compound 3, half-maximal inhibitory concentration: > 100000 nM
Compound 3 ended at the assay's limit; the forecaster's own chance of this, stated with the estimate: 40%; middle value at least 3.3-fold (0.52 log units) away from the limit.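

In this assay compound 3, like compound 2, gives only a limit and not a number, so the step between them cannot be read, and adding trifluoromethyl to this ring brings no measurable value. With trifluoromethyl present in both, methoxy in place of chloro on an aromatic carbon gives an at least 12-fold higher number from compound 1 to compound 3 (1.07 log units; beyond the scatter). Any further loss cannot be seen: the limit of > 100000 nM in this assay, at which 2 of the 3 values shown sit.

The compounds shown leave open whether chloro would give a measurable value without trifluoromethyl. They also leave open how an amine or a carboxylic acid at the methoxy position would read.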